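Swapping Trifluoromethyl for Trifluoromethoxy on a Glucagon Antagonist

This account rests on a few compounds, and the source may have more. Where it says the series, first, only, none or still open, it means among the compounds named here.

Compound 2 `CC(C)(C)[C@H]1CC[C@]2(CC1)N=C(c1ccc(C(F)(F)F)cc1)C(=O)N2Cc1ccc(C(=O)NCCC(=O)O)cc1` carries a 4-(trifluoromethyl)phenyl group on a carbon with a double bond to nitrogen. For the measured compounds named here, in a functional assay on CHO cells for antagonist activity at Glucagon receptor (Homo sapiens), read by cAMP accumulation, with stated times of 30 min and 45 min (a lower number here means a stronger inhibitor, a higher number a weaker inhibitor), compound 2 gives 800 nM, the highest of the two numbers measured so far. Compound 1 `CC(C)(C)[C@H]1CC[C@]2(CC1)N=C(c1cccc(C(F)(F)F)c1)C(=O)N2Cc1ccc(C(=O)NCCC(=O)O)cc1` gives 510 nM in this assay, and the step of a 1.6-fold higher number from compound 1 to compound 2 (0.20 log units; within the scatter) concerns a different change, not the one made here. Compound 3 `CC(C)(C)[C@H]1CC[C@]2(CC1)N=C(c1ccc(OC(F)(F)F)cc1)C(=O)N2Cc1ccc(C(=O)NCCC(=O)O)cc1` differs from compound 2 only by trifluoromethoxy in place of trifluoromethyl on an aromatic carbon. Going by the values given here, no measured step tests this change, so compound 3 is expected to sit close to compound 2, with a step of a 1.1-fold lower number from compound 2 to compound 3 (0.06 log units; within the scatter) estimated. The estimate for compound 3 is 700 nM, with a range from 250 nM to 2000 nM.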

Compound 3, half-maximal inhibitory concentration: 1900 nM
Beside the measured number, compound 3's estimate is 2.7-fold (0.43 log units) below it; low and high end bracket the measured number.
By their numbers in this assay, from the lowest: compounds 1 and 2 (each within the scatter of the next); then compound 3.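

Trifluoromethoxy in place of trifluoromethyl on this aromatic carbon gives a 2.4-fold higher number from compound 2 to compound 3 (0.38 log units; beyond the scatter) in this assay and so shows that the group held here can change the number beyond the scatter, which the earlier pair of compounds did not show. The 4-(trifluoromethoxy)phenyl group also compares unfavourably with 3-(trifluoromethyl)phenyl, with a 3.7-fold higher number from compound 1 to compound 3 (0.57 log units; beyond the scatter) as the step. Nothing available explains why the number rises.

Going by these compounds, whether an amine, a nitrile or a longer chain on this aromatic carbon would give a lower number remains open.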